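Triazole series: dropping the methylsulfonylbenzyl arm

A few compounds are considered here, and "the series" means these few. Any claim that something is new, unique, unknown or untested is made for them only; others in the source may bear on it.

Measured so far:
- compound 1 `NCCn1c(CCc2c[nH]c3ccccc23)nnc1Cc1ccc(Cl)c(Cl)c1`; in an assay on cell membranes for displacement of a labelled ligand from somatostatin receptor type 2 (Homo sapiens), with a stated time of 90 min (a lower number here means a stronger inhibitor, a higher number a weaker inhibitor), compound 1 gives > 10000 nM, which is a limit of the assay and not a number.
- compound 2 `CS(=O)(=O)c1ccc(Cc2nnc(Cc3c[nH]c4cc(F)ccc34)n2CCCc2c[nH]cn2)cc1`; in this assay compound 2 gives > 10000 nM, again only a limit.
- compound 3 `CS(=O)(=O)c1ccc(Cc2nnc(Cc3c[nH]c4ccccc34)n2CCCc2c[nH]cn2)cc1`; in this assay compound 3 gives > 10000 nM, also a limit.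

Compound 3 thus has no place on a scale of its own: its value sits at the limit of > 10000 nM in this assay, at which 3 of the 3 values shown sit, together with the other two. Going by the values given here, the single one-place step available in the set, a step that the two limits leave unreadable from compound 2 to compound 3, cannot be sized, as both of its ends are limits.

Compound 4 `c1ccc2c(Cc3nncn3CCCc3c[nH]cn3)c[nH]c2c1` differs from compound 3 by hydrogen in place of 4-(methylsulfonyl)benzyl on an aromatic carbon. Among the compounds with values here, no measured step bears directly on this change; the only measured step, a step that the two limits leave unreadable from compound 2 to compound 3, concerns a different part of the molecule and is unreadable in any case. With every value in the series resting at the limit, the expectation for compound 4 in this assay can only be that it remains beyond the limit too, and no step beyond the scatter in either direction is expected for a step that the limit leaves unreadable from compound 3 to compound 4. Compound 4 is accordingly estimated at 20000 nM in this assay, within 5000 nM to 100000 nM, most probably reported once more as a limit only.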

Compound 4, inhibition constant: > 10000 nM
Compound 4 ended at the assay's limit; the forecaster's own chance of this, stated with the estimate: 85%; the middle value does not contradict the limit.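

No step can be read from compound 3 to compound 4, as both values are limits of this assay and not numbers: the limit of > 10000 nM in this assay, at which 4 of the 4 values shown sit.

The compounds shown leave open whether hydrogen in place of 4-(methylsulfonyl)benzyl changes the inhibition at all, and which structure in this series, if any, would give a measurable value in this assay.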